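From fluoro to amino: what compound 3 may show

The source may report more compounds than this note shows. Statements on the series, on what has been measured and on what is new or still open speak of the compounds shown alone.

Measured so far in a functional assay on SW480 cells (Homo sapiens) for cytotoxicity, read by MTT assay, with a stated time of 48 h; a higher number here means a weaker inhibitor, a lower number a stronger inhibitor:
- Compound 1 `COc1cc(C(=O)c2cn(-c3cccc(N)c3)cc2-c2ccc(N)cc2)cc(OC)c1OC`: 48 nM
- Compound 2 `COc1cc(C(=O)c2cn(-c3ccc(F)cc3)cc2-c2ccc(N)cc2)cc(OC)c1OC`: 167 nM

Compound 2, at 167 nM, holds the higher of the two numbers, which makes it the weaker inhibitor of the pair. Compound 3 `COc1cc(C(=O)c2cn(-c3ccc(N)cc3)cc2-c2ccc(N)cc2)cc(OC)c1OC` departs from compound 2 at one place: amino in place of fluoro on an aromatic carbon. This is amino in place of fluoro on an aromatic carbon, turning 4-fluorophenyl into 4-aminophenyl.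

Going by the values given here, only one measured step bears on this change: a 3.5-fold higher number from compound 1 to compound 2 (0.54 log units; beyond the scatter). It is modest but beyond the scatter, and it comes from 4-fluorophenyl in place of 3-aminophenyl on an aromatic nitrogen. Among the compounds with values here, the match is only partial, since compound 1 carries 3-aminophenyl while compound 3 carries 4-aminophenyl, and no measured compound compares those two groups. A step of similar or somewhat smaller size is therefore expected in this assay, towards a lower number. The estimated change is a 2.4-fold lower number from compound 2 to compound 3 (0.38 log units; beyond the scatter). For compound 3 the estimated value is 70 nM, with an expected range from 25 nM to 190 nM.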

Compound 3, half-maximal inhibitory concentration: 153 nM
Compound 3: the middle estimate sits 2.2-fold (0.34 log units) below what was measured; low and high end bracket the measured number.
By their numbers in this assay, from the lowest: compound 1; then compounds 3 and 2 (each within the scatter of the next).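

In this assay, the step of a 1.1-fold lower number from compound 2 to compound 3 (0.04 log units; within the scatter) shows that, on this aromatic carbon para to a large group, fluoro and amino give numbers that cannot be told apart, so the amino group alone does not bring the lower number seen for compound 1. The step of a 3.2-fold higher number from compound 1 to compound 3 (0.50 log units; beyond the scatter) points to where the amino group sits on the phenyl ring as what matters among these three compounds: with the same two atoms of the core kept and only 3-aminophenyl changed to 4-aminophenyl, the number rises beyond the scatter, and compound 1 remains the only one that stands apart from the other two. No independent measurement is available to explain this difference between the two aminophenyl groups.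

The compounds shown leave open whether 3-fluorophenyl would match compound 1 or stay with compound 2 and compound 3, which would tell whether this place on the ring favours any group or the amino group in particular. On these data alone, it also remains open whether a 3-hydroxyphenyl or 2-aminophenyl group would keep a number as low as that of compound 1.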